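Swapping the methoxyphenyl for a second bromophenyl

The source may hold more compounds than are shown below. What is called first, only, known or untested is meant among the compounds shown, and "the series" means these compounds.

Compound 2 `C=CCn1c(=O)/c(=C\c2cccc(Br)c2)[nH]c(=O)/c1=C\c1ccccc1OC` carries a 3-bromophenyl on one side of the shared core and a 2-methoxyphenyl on the other. In a functional assay on U-937 cells (Homo sapiens) for cytotoxicity, read by CCK-8 assay, with a stated time of 72 h (on this read-out lower numbers stand for stronger inhibition and higher numbers for weaker inhibition), compound 2 gives 1100 nM, the highest of the two numbers available. Its nearest neighbour is compound 1 `C=CCn1c(=O)/c(=C\c2ccccc2Cl)[nH]c(=O)/c1=C\c1ccccc1OC`, which in this assay gives 700 nM; the step of a 1.6-fold higher number from compound 1 to compound 2 (0.20 log units; within the scatter) lies within the scatter, so the two cannot be told apart. Compound 3 `C=CCn1c(=O)/c(=C\c2ccc(F)c(Br)c2)[nH]c(=O)/c1=C\c1ccccc1OC` is reported in this assay as "not active" (no number reported), with no number given.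

Compound 4 `C=CCn1c(=O)/c(=C\c2cccc(Br)c2)[nH]c(=O)/c1=C\c1cccc(Br)c1` differs from compound 2 by 3-bromophenyl in place of 2-methoxyphenyl on a double-bonded chain carbon bound to an aromatic carbon. Among the compounds with values here, no measured step touches this group: the step from compound 1 to compound 2 exchanged the other aryl substituent and left the 2-methoxyphenyl in place. Within the data shown here, the only guidance is that varying aryl groups has so far produced a change within the scatter for compound 1 against compound 2, and a loss of any measurable number for compound 3. Compound 4 is therefore expected to give roughly 1500 nM in this assay, somewhere between 500 nM and 5000 nM, meaning an expected step of a 1.4-fold higher number from compound 2 to compound 4 (0.13 log units; within the scatter) that might well sit within the scatter.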

Compound 4, half-maximal inhibitory concentration: "not active" (no number reported)
Compound 4 has no reported number here; no gap can be computed for the estimate.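

Within the data shown here, compound 4 is reported as not active and carries no number, so no step from compound 2 to compound 4 can be read. Nothing measured here offers an explanation for this result. The compounds shown leave open how far compound 4 lies from compound 2, and whether losing the 2-methoxyphenyl alone accounts for the missing number.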